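Swapping the Aryl Group: An Expected Value for Compound 4

The source may report more compounds than this note shows. Statements on the series, on what has been measured and on what is new or still open speak of the compounds shown alone.

Measured so far:
- Compound 1, `CCCS(=O)(=O)Nc1ccc(F)c(C(=O)c2n[nH]c3ncc(-c4cccc(Cl)c4)cc23)c1F`: 40%
- Compound 2, `CCCS(=O)(=O)Nc1ccc(F)c(C(=O)c2n[nH]c3ncc(-c4cccc(N(C)C)c4)cc23)c1F`: 26%
- Compound 3, `CCCS(=O)(=O)Nc1ccc(F)c(C(=O)c2n[nH]c3ncc(-c4ccc(S(=O)(=O)NC)cc4)cc23)c1F`: 1.2%

All three compounds share one core and differ only in the aryl group attached to it. In an assay for binding affinity to dual specificity mitogen-activated protein kinase kinase 4 (Homo sapiens), read by KINOMEscan, tested at 100 nM (on this read-out lower numbers stand for a stronger effect and higher numbers for a weaker effect at the one concentration tested), compound 2 gives 26%, the second highest of the three numbers: it sits below compound 1 by a number 14 percentage points lower from compound 1 to compound 2 (beyond the scatter) and above compound 3 by a number 24.8 percentage points lower from compound 2 to compound 3 (beyond the scatter), both steps beyond the scatter.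

Compound 4, `CCCS(=O)(=O)Nc1ccc(F)c(C(=O)c2n[nH]c3ncc(-c4ccc(NS(C)(=O)=O)cc4)cc23)c1F`, has not been measured. It differs from compound 2 in one place: 4-(methanesulfonamido)phenyl in place of 3-(dimethylamino)phenyl on an aromatic carbon.

Among the compounds with values here, two measured steps bear on this change. The step of a number 24.8 percentage points lower from compound 2 to compound 3 (beyond the scatter) and the step of a number 38.8 percentage points lower from compound 1 to compound 3 (beyond the scatter) both replace an aryl group carrying a chloro or dimethylamino substituent with a 4-substituted aryl group bearing a sulfur-containing, hydrogen-bond-donating group, and both lower the number strongly. The entering 4-(methanesulfonamido)phenyl resembles the 4-(methylsulfamoyl)phenyl of compound 3 in size and in donor and acceptor count, so a step of similar direction is expected, though its exact size is uncertain.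

Compound 4 is therefore expected to give 6%, within a range from 1% to 20%, corresponding to an expected step of a number 20 percentage points lower from compound 2 to compound 4 (beyond the scatter).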

Compound 4, a percentage reported as activity, at one concentration (the size of the read-out at that concentration, not a potency): 0.85%
For compound 4 the middle estimate is 5.2 percentage points above the measured one; measured number below the stated range.
By their numbers in this assay, from the lowest: compounds 4 and 3 (each within the scatter of the next); then compound 2; then compound 1.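

Compound 3 alone could not show whether its low number was tied to the methylsulfamoyl group, but in this assay the step to methanesulfonamido, a number 0.4 percentage points lower from compound 3 to compound 4 (within the scatter), shows that these two groups cannot be told apart on this read-out at this position of the shared core. The second sulfur-containing aryl group also separates from the other two compounds, with a number 25.2 percentage points lower from compound 2 to compound 4 (beyond the scatter) and a number 39.2 percentage points lower from compound 1 to compound 4 (beyond the scatter), so the low number in this assay is no longer seen with a single group only. No supporting evidence is available to explain why the two groups give such similar numbers.

Each step away from 3-chlorophenyl or 3-(dimethylamino)phenyl changes both the substituent and where it stands on the phenyl ring, so the compounds shown do not separate these two changes. They also leave open whether sulfur is needed at all, a question that a phenyl ring carrying a carboxylic acid or an amine in the same place could address.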